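Adding a Methoxy Group to the Aryl Ring of Compound 2

The source may hold more compounds than are shown below. What is called first, only, known or untested is meant among the compounds shown, and "the series" means these compounds.

Compound 1 `O=C1C[C@H](OCc2cc(-c3ccccc3)no2)[C@H]2CO[C@@H]1O2`: 21900 nM in a functional assay on MDA-MB-231 cells (Homo sapiens) for cytotoxicity, read by MTT assay, with a stated time of 48 h; a higher number here means a weaker inhibitor, a lower number a stronger inhibitor
Compound 2 `O=C1C[C@H](OCc2cc(/C=C/c3ccccc3)no2)[C@H]2CO[C@@H]1O2`: 22900 nM in this assay

In this assay, among the measured compounds shown here, compound 2 gives 22900 nM, the higher of the two numbers measured so far, with compound 1 nearest at 21900 nM. The step of a 1.0-fold higher number from compound 1 to compound 2 (0.02 log units; within the scatter) stays within the scatter. Compound 3 `COc1ccc(/C=C/c2cc(CO[C@H]3CC(=O)[C@@H]4OC[C@H]3O4)on2)cc1` differs from compound 2 by methoxy in place of hydrogen on an aromatic carbon. For the measured compounds named here, no measured step covers this change, and the single step known is flat, so the author expects a step of a 1.1-fold lower number from compound 2 to compound 3 (0.06 log units; within the scatter) in this assay, no larger than the scatter. Compound 3 is therefore estimated at 20000 nM, within a range of 8000 nM to 50000 nM.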

Compound 3, half-maximal inhibitory concentration: 26400 nM
Compound 3: middle estimate off by 1.3-fold (0.12 log units), on the low side, within the range that was stated.
By their numbers in this assay, from the lowest: compounds 1, 2 and 3 (each within the scatter of the next).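

Putting methoxy on the aromatic ring, para to a large group, turns phenyl into 4-methoxyphenyl and gives a 1.2-fold higher number from compound 2 to compound 3 (0.06 log units; within the scatter) in this assay without moving the number beyond the scatter. Compound 2 had shown only that 2-phenylethenyl could replace phenyl, whereas compound 3 shows that the ring of that group can also carry a substituent at this position with a flat result. No available evidence bears on this result.
On these data alone, whether an amine or a carboxylic acid at this position would give a step beyond the scatter remains open.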